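Swapping the amide aryl group of a flavonol series

The compounds below may be only part of what the source reports. "The series", "measured", "known", "first", "only" and "open" are said of these compounds alone.

Of the compounds shown here, three sharing one core have been tested in a functional assay on A549 cells (Homo sapiens) for antiproliferative activity, read by CCK-8 assay, with a stated time of 72 h; a higher number here means a weaker inhibitor, a lower number a stronger inhibitor. Compound 1 `O=C(Nc1cccc(-c2oc3cc(-c4ccc(F)cc4)ccc3c(=O)c2O)c1)c1ccc(F)cc1` gives 6930 nM. Compound 2 `COc1ccc(C(=O)Nc2cccc(-c3oc4cc(-c5ccc(F)cc5)ccc4c(=O)c3O)c2)cc1` gives 8700 nM, and compound 3 `Cc1ccc(C(=O)Nc2cccc(-c3oc4cc(-c5ccc(F)cc5)ccc4c(=O)c3O)c2)cc1` gives 6910 nM. Compound 2 carries the highest of the three numbers, yet its distance to each of the others is within the scatter: a 1.3-fold higher number from compound 1 to compound 2 (0.10 log units; within the scatter) and a 1.3-fold lower number from compound 2 to compound 3 (0.10 log units; within the scatter), with a 1.0-fold lower number from compound 1 to compound 3 (0.00 log units; within the scatter) closing the triangle.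

The next compound is compound 4 `Cc1cc(C(=O)Nc2cccc(-c3oc4cc(-c5ccc(F)cc5)ccc4c(=O)c3O)c2)ccc1F`, reached from compound 2 by 4-fluoro-3-methylphenyl in place of 4-methoxyphenyl on a carbonyl carbon. The bearing steps are those that exchange the group on the same carbonyl carbon among fluoro, methoxy and methyl on the aromatic carbon; all three were within the scatter, so this part of the molecule has so far moved the number little. For the measured compounds named here, compound 4 combines fluoro and methyl in one ring, and no measured step tests that combination directly. A step of no size beyond the scatter is therefore expected in this assay, leaning slightly downward because compound 3 shows 6910 nM against compound 2.

Compound 4 is expected to give 6500 nM, with a range from 3300 nM to 13000 nM. The expected step is a 1.3-fold lower number from compound 2 to compound 4 (0.13 log units; within the scatter).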

Compound 4, half-maximal inhibitory concentration: 11500 nM
The estimate for compound 4 lay 1.8-fold (0.25 log units) below the measured number; low and high end bracket the measured number.
By their numbers in this assay, from the lowest: compounds 3, 1, 2 and 4 (each within the scatter of the next).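

In this assay, a ring carrying two substituents on the carbonyl carbon still gives only steps within the scatter: a 1.3-fold higher number from compound 2 to compound 4 (0.12 log units; within the scatter), a 1.7-fold higher number from compound 3 to compound 4 (0.22 log units; within the scatter) and a 1.7-fold higher number from compound 1 to compound 4 (0.22 log units; within the scatter). These three steps extend the earlier picture from single exchanges on the ring to 4-fluoro-3-methylphenyl, which replaces 4-methoxyphenyl in one step and 4-methylphenyl in another, and in the third differs from the ring of compound 1 by one added methyl group; across all four compounds, none of these changes moves the number beyond the scatter. No measurement shown here explains these numbers or bears on the result.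

As far as these compounds go, all four compounds carry a substituted phenyl on this carbonyl carbon, so it remains open whether this position can move the number beyond the scatter at all, for instance with a dimethylamino group, a carboxylic acid or a longer alkyl chain on the ring, or with a saturated ring such as piperidine in place of the phenyl. The compounds shown also leave open how the number responds to changes elsewhere on the shared core, such as at its hydroxyl group.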